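The source may hold more compounds than are shown below. What is called first, only, known or untested is meant among the compounds shown, and "the series" means these compounds.

Working notes on the series. Compound 1 `CCCCCCCCCCCCCCNc1nc(SCc2ccc(C(F)(F)F)cc2)nc2ccccc12`, compound 2 `FC(F)(F)c1ccc(CSc2nc(Nc3ccccc3)c3ccccc3n2)cc1` and compound 3 `Cc1ccccc1Nc1nc(SCc2ccc(C(F)(F)F)cc2)nc2ccccc12` share one core and differ only in the group carried on a nitrogen on an aromatic ring. In a functional assay on MDA-MB-231 cells (Homo sapiens) for cytotoxicity, read by MTT assay, with a stated time of 72 h (on this read-out higher numbers stand for weaker inhibition and lower numbers for stronger inhibition), compound 1 returns only a limit of the assay, > 50000 nM, which is not a number (the limit of > 50000 nM in this assay, at which 1 of the 3 values shown sits). In this assay compound 2 gives 18400 nM. In this assay compound 3 gives 27100 nM. Among the measured compounds shown here, the single-point step a 1.5-fold higher number from compound 2 to compound 3 (0.17 log units; within the scatter) is the only one with numbers on both sides, and it lies within the scatter. Compound 3 therefore stands at the higher of the two measured numbers, with compound 2 nearest and within the scatter of it, while the limit of compound 1 cannot be placed in order against compound 3.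

Compound 4 `COc1cc(Nc2nc(SCc3ccc(C(F)(F)F)cc3)nc3ccccc23)cc(OC)c1` is next. The change from compound 3 is 3,5-dimethoxyphenyl in place of 2-methylphenyl on a nitrogen on an aromatic ring. For the measured compounds named here, no measured step touches the 3,5-dimethoxyphenyl group itself; the only related step, a 1.5-fold higher number from compound 2 to compound 3 (0.17 log units; within the scatter), altered the same aryl group and stayed within the scatter. For compound 4 the expected step is a 1.4-fold lower number from compound 3 to compound 4 (0.13 log units; within the scatter), with no clear direction. For compound 4 the estimate in this assay is 20000 nM, expected between 5000 nM and 60000 nM, with some chance that the assay again returns only a limit.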

Compound 4, half-maximal inhibitory concentration: 16100 nM
Beside the measured number, compound 4's estimate is 1.2-fold (0.09 log units) above it; measured number inside the range.
By their numbers in this assay, from the lowest: compounds 4, 2 and 3 (each within the scatter of the next). At a limit, above all of these: compound 1.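

The 3,5-dimethoxyphenyl group, which brings hydrogen-bond acceptors that 2-methylphenyl does not have, leaves the number in this assay within the scatter of the 2-methylphenyl compound (a 1.7-fold lower number from compound 3 to compound 4 (0.23 log units; within the scatter)) and of the unsubstituted phenyl compound (a 1.1-fold lower number from compound 2 to compound 4 (0.06 log units; within the scatter)). With the earlier step between compound 2 and compound 3 also within the scatter, the three aryl groups on this nitrogen on an aromatic ring cannot be told apart in this assay, and the larger change in compound 4 separates them no better than the single methyl did. Compound 1 still gives only a limit of the assay, not a number, so it cannot be placed in order against these aryl compounds: the limit of > 50000 nM in this assay, at which 1 of the 4 values shown sits.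

From the compounds shown here alone, whether any group on this nitrogen moves the number beyond the scatter remains open, for example an aryl group carrying a carboxylic acid or an amine, or an alkyl chain shorter than that of compound 1. Going by these compounds, the rest of the structure is the same in all four compounds, so what the trifluoromethyl group contributes in this assay also stays unknown.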